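Piperidin-1-yl for cyclopropylamino: working notes

The source may hold more compounds than are shown below. What is called first, only, known or untested is meant among the compounds shown, and "the series" means these compounds.

Measured in a functional assay on HepG2 cells (Homo sapiens) for inhibition, with a stated time of 72 h; a lower number here means a stronger inhibitor, a higher number a weaker inhibitor:
- compound 1 `O=C(Nc1ccccc1)Nc1nc(NC2CC2)cc(Sc2c[nH]c3ccccc23)n1`: 14300 nM
- compound 2 `Cc1cc(Cl)ccc1NC(=O)Nc1nc(NC2CC2)cc(Sc2c[nH]c3ccccc23)n1`: 9740 nM

Among the measured compounds shown here, compound 1 has the higher number, but it cannot be separated from compound 2: the only measured step, a 1.5-fold lower number from compound 1 to compound 2 (0.17 log units; within the scatter), lies within the scatter. That step concerns an amide-type nitrogen, where 4-chloro-2-methylphenyl replaces phenyl. For the measured compounds named here, no measured step covers the change in compound 3 `O=C(Nc1ccccc1)Nc1nc(Sc2c[nH]c3ccccc23)cc(N2CCCCC2)n1`, which has piperidin-1-yl in place of cyclopropylamino on an aromatic carbon. No shift beyond the scatter is therefore expected in this assay, in either direction, and the estimated step is a 1.0-fold higher number from compound 1 to compound 3 (0.02 log units; within the scatter). For compound 3 the estimate is 15000 nM, with an expected range of 5000 nM to 45000 nM.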

Compound 3, half-maximal inhibitory concentration: 20900 nM
Compound 3: middle estimate off by 1.4-fold (0.14 log units), on the low side, and the stated range covers the measured number.
By their numbers in this assay, from the lowest: compounds 2, 1 and 3 (each within the scatter of the next, the first and the last beyond it).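

In this assay, piperidin-1-yl in place of cyclopropylamino on this aromatic carbon gives a 1.5-fold higher number from compound 1 to compound 3 (0.16 log units; within the scatter). The first change shown at this position, it swaps a group with 1 hydrogen-bond donor for one with 0 and a three-membered ring for a six-membered one, with no shift beyond the scatter. No evidence bears on the reason for this result.

Open, on these data alone, is whether morpholin-4-yl or an open-chain amine such as dimethylamino on this carbon would move the number beyond the scatter. Also open, as far as these compounds go, is how piperidin-1-yl behaves alongside 4-chloro-2-methylphenyl.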